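Cytotoxicity notes on a rearranged amidoxime pair

The source may report more compounds than this note shows. Statements on the series, on what has been measured and on what is new or still open speak of the compounds shown alone.

Compound 1 `CC1(Cc2ccccc2)CC(S(=O)(=O)c2ccc(Nc3ccc(/C(N)=N/O)cc3)cc2)=C(c2ccc(/C(N)=N/O)cc2)O1` and compound 2 `N/C(=N\O)c1ccc(S(=O)(=O)C2=C(c3ccc(Nc4cccc(/C(N)=N/O)c4)cc3)OC(c3ccccc3)(c3ccccc3)C2)cc1` form the measured set. In an ADME assay on THP-1 cells (Homo sapiens) for cytotoxicity, read by flow cytometry, with a stated time of 72 h (on this read-out lower numbers stand for stronger inhibition and higher numbers for weaker inhibition), compound 1 gives 47600 nM; in this assay compound 2 gives 48100 nM. For the measured compounds named here, the two numbers are within the scatter of each other, so compound 1 stands level with its only neighbour and nothing in the measured pair points in any direction. Compound 3 `CC1(Cc2ccccc2)CC(S(=O)(=O)c2ccc(Nc3ccccc3/C(N)=N/O)cc2)=C(c2ccc(/C(N)=N/O)cc2)O1` is the unmeasured analogue. It differs from compound 1 by a group of 10 heavy atoms (7 carbon, 2 nitrogen, 1 oxygen; one six-membered aromatic ring of carbon only) in place of a group of 10 heavy atoms (7 carbon, 2 nitrogen, 1 oxygen; one six-membered aromatic ring of carbon only), on a nitrogen on an aromatic ring. Going by the values given here, no step between measured compounds covers a change of this kind, and both measured numbers sit close together. The estimated step is a 1.1-fold lower number from compound 1 to compound 3 (0.02 log units; within the scatter), not beyond the scatter. Compound 3 is expected to give about 45000 nM in this assay, with a range from 20000 nM to 100000 nM.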

Compound 3, half-maximal inhibitory concentration: 48400 nM
Estimate against measurement, compound 3: 1.1-fold (0.03 log units) below; measured number inside the range.
By their numbers in this assay, from the lowest: compounds 1, 2 and 3 (each within the scatter of the next).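

In this assay, exchanging one group of 10 heavy atoms (7 carbon, 2 nitrogen, 1 oxygen; one six-membered aromatic ring of carbon only) for another of the same atoms, joined differently, on a nitrogen on an aromatic ring gives a 1.0-fold higher number from compound 1 to compound 3 (0.01 log units; within the scatter). The earlier compounds shown here offered no step in one place, whereas this pair shows that this particular rearrangement at this position leaves the read-out level. No supporting measurement bears on why the number stays level.

Still open, on these data alone, is whether a group on that nitrogen carrying a carboxylic acid or an amine in place of the amidoxime would give a step beyond the scatter. As far as these compounds go, the same rearrangement on the core of compound 2 also remains open.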